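This account rests on a few compounds, and the source may have more. Where it says the series, first, only, none or still open, it means among the compounds named here.

Compound 1 `CC(C)NC(=O)C1=CC(C)(C)Oc2ccc([N+](=O)[O-])cc21`: 77.6%
Compound 2 `C#CCNC(=O)C1=CC(C)(C)Oc2ccc([N+](=O)[O-])cc21`: 80.2%

In a functional assay on the whole organism (muscle tissue) with Rattus norvegicus as the target (on this read-out lower numbers stand for smaller maximal responses and higher numbers for larger maximal responses), compound 2 gives 80.2%, and compound 1 gives 77.6%; the two lie within the scatter of each other, so neither can be ranked. Compound 3 `CC1(C)C=C(C(N)=O)c2cc([N+](=O)[O-])ccc2O1` differs from compound 2 by hydrogen in place of propargyl on an amide-type nitrogen. For the measured compounds named here, the only measured step, a number 2.6 percentage points higher from compound 1 to compound 2 (within the scatter), swapped one group for another on that nitrogen without any change beyond the scatter, so no step beyond the scatter is expected from compound 2 to compound 3 in this assay either: an estimated a number 2.2 percentage points lower from compound 2 to compound 3 (within the scatter). Compound 3 is thus expected to give 78%, between 62% and 92%.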

Compound 3, intrinsic activity: the largest response reached, in percent of the reference agonist's: 79.8%
Compound 3: the middle estimate sits 1.8 percentage points below what was measured, and the stated range covers the measured number.
By their numbers in this assay, from the lowest: compounds 1, 3 and 2 (each within the scatter of the next).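

In this assay, the bare amide with only hydrogen on the nitrogen stays within the scatter of both substituted amides: hydrogen replacing propargyl gives (a number 0.4 percentage points lower from compound 2 to compound 3 (within the scatter)) and hydrogen replacing isopropyl gives (a number 2.2 percentage points higher from compound 1 to compound 3 (within the scatter)). Among these three compounds, then, the maximal response does not depend on a carbon group being present on this amide-type nitrogen. No supporting measurement explains this result. Still open, as far as these compounds go, is whether a longer chain, a benzyl group or a chain ending in an amine on this nitrogen would keep the response within the same scatter.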